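Acetyl in Place of a Keto Ester Tail

A few compounds are considered here, and "the series" means these few. Any claim that something is new, unique, unknown or untested is made for them only; others in the source may bear on it.

Measured in a functional assay on CCRF-CEM cells (Homo sapiens); on this read-out lower numbers stand for higher toxicity in this test and higher numbers for lower toxicity in this test:
Compound 1 `CCNC(=O)NC1=CS(=O)(=O)O[C@@]12[C@@H](CO[Si](C)(C)C(C)(C)C)O[C@@H](n1cc(C)c(=O)n(C)c1=O)[C@@H]2O[Si](C)(C)C(C)(C)C` gives 4260 nM.
Compound 2 `COC(=O)C(=O)CNC1=CS(=O)(=O)O[C@@]12[C@@H](CO[Si](C)(C)C(C)(C)C)O[C@@H](n1cc(C)c(=O)n(C)c1=O)[C@@H]2O[Si](C)(C)C(C)(C)C` gives 5570 nM.
Compound 3 `Cc1cn([C@@H]2O[C@@H]3COC4(O)CS(=O)(=O)O[C@@]34[C@H]2O[Si](C)(C)C(C)(C)C)c(=O)[nH]c1=O` gives 100000 nM.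

Among these three numbers, compound 2 stands second highest; its nearest neighbour is compound 1, within the scatter, and its furthest is compound 3, well beyond it. Within the data shown here, the only change made so far at the amine nitrogen is a 1.3-fold higher number from compound 1 to compound 2 (0.12 log units; within the scatter), which stayed within the scatter. The move from compound 2 to the not yet measured compound 4 `CC(=O)NC1=CS(=O)(=O)O[C@@]12[C@@H](CO[Si](C)(C)C(C)(C)C)O[C@@H](n1cc(C)c(=O)n(C)c1=O)[C@@H]2O[Si](C)(C)C(C)(C)C` touches the same nitrogen: acetyl in place of ((methoxycarbonyl)carbonyl)methyl on an amine nitrogen. Compound 3 differs from the others in more than one place and gives no direct comparison, so the step from compound 1 to compound 2 is the one that bears here. A number close to that of compound 2 is expected for compound 4, because a 1.3-fold higher number from compound 1 to compound 2 (0.12 log units; within the scatter) shows that exchanging the group on this nitrogen left the read-out within the scatter. The expected step is thus a 1.2-fold lower number from compound 2 to compound 4 (0.09 log units; within the scatter). Compound 4 is therefore estimated at 4500 nM, expected to lie between 1500 nM and 13000 nM.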

Compound 4, half-maximal cytotoxic concentration: 25700 nM
Compound 4: middle estimate off by 5.7-fold (0.76 log units), on the low side; measured number above the stated range.
By their numbers in this assay, from the lowest: compounds 1 and 2 (each within the scatter of the next); then compound 4; then compound 3.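

The nitrogen is less forgiving than the first exchange suggested. In this assay, acetyl in place of ((methoxycarbonyl)carbonyl)methyl gives a 4.6-fold higher number from compound 2 to compound 4 (0.66 log units; beyond the scatter), and methyl in place of ethylamino on a carbonyl carbon gives a 6.0-fold higher number from compound 1 to compound 4 (0.78 log units; beyond the scatter), both towards lower toxicity in this test, so a change confined to the group on the carbonyl carbon is enough to move the read-out. No measurement at hand explains this shift.

From the compounds shown here alone, whether a free amine on this nitrogen, or a longer chain such as propanoyl in place of acetyl, would carry the number further remains open. So does whether a carboxylic acid in place of the methoxycarbonyl end of compound 2 would stay near compound 2 or move towards compound 4.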